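The source may hold more compounds than are shown below. What is called first, only, known or untested is meant among the compounds shown, and "the series" means these compounds.

Measured compounds:
compound 1 `CCCCCCCCn1cc(CO[C@H]2CC(=O)[C@@H]3OC[C@H]2O3)nn1` — in a functional assay on MDA-MB-231 cells (Homo sapiens) for cytotoxicity, read by MTT assay, with a stated time of 48 h (a lower number here means a stronger inhibitor, a higher number a weaker inhibitor), compound 1 gives > 50000 nM, which is a limit of the assay.
compound 2 `O=C1C[C@H](OCc2cn(-c3ccc(Cl)cc3)nn2)[C@H]2CO[C@@H]1O2` — in this assay compound 2 gives 26100 nM.

Among the compounds with values here, compound 2 carries the only number among the two values shown; the other value is a limit (the limit of > 50000 nM in this assay, at which 1 of the 2 values shown sits). Against compound 1, the one measured step is an at least 1.9-fold lower number from compound 1 to compound 2 (0.28 log units; that floor lies within the scatter), and its floor lies within the scatter, so the two compounds are not clearly separated.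

Compound 3 `C=C(C)Cn1cc(CO[C@H]2CC(=O)[C@@H]3OC[C@H]2O3)nn1` differs from compound 2 by 2-methylprop-2-en-1-yl in place of 4-chlorophenyl on an aromatic nitrogen. Within the data shown here, the only step that bears on this change is the one from compound 1 to compound 2, where an octyl chain gave way to the same 4-chlorophenyl and the number moved by an at least 1.9-fold lower number from compound 1 to compound 2 (0.28 log units; that floor lies within the scatter). Compound 3 goes back from the 4-chlorophenyl to a chain, the 2-methylprop-2-en-1-yl group, so a move back toward the weaker end of the pair is expected, with a real chance that only a limit is returned. Compound 3 is estimated at 40000 nM, in the range 15000 nM to 100000 nM, which amounts to an expected step of a 1.5-fold higher number from compound 2 to compound 3 (0.19 log units; within the scatter).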

Compound 3, half-maximal inhibitory concentration: 26700 nM
The estimate for compound 3 lay 1.5-fold (0.18 log units) above the measured number, and the stated range covers the measured number.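

In this assay, the exchange on the aromatic nitrogen of the five-membered aromatic ring gives a 1.0-fold higher number from compound 2 to compound 3 (0.01 log units; within the scatter), so 4-chlorophenyl and 2-methylprop-2-en-1-yl are not separated, and in this pair a six-membered aromatic ring at this position is not needed for a number of this size. The comparison of the two chain-bearing compounds gives an at least 1.8-fold lower number from compound 1 to compound 3 (0.27 log units; that floor lies within the scatter), so a short branched unsaturated chain in place of the octyl chain is also not clearly separated, as the floor of that step lies within the scatter. Compound 1 stands at a limit of the assay and not at a number, so its true distance from the other compounds stays unknown: the limit of > 50000 nM in this assay, at which 1 of the 3 values shown sits.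

Going by these compounds, it remains open whether any group on this nitrogen can give a number clearly separated from those of compound 2 and compound 3, since the readable values so far lie within the scatter of each other. On these data alone, the effect of a benzyl group, an aminoethyl chain or a carboxylic acid at this place also remains open.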